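Methylpiperazine in Place of Piperidine on a Shared Core

The source may hold more compounds than are shown below. What is called first, only, known or untested is meant among the compounds shown, and "the series" means these compounds.

Of the compounds shown here, three built on one shared core have been measured in an assay on cells for displacement of a labelled ligand from adenosine receptor A3 (Homo sapiens), read by scintillation counting and radioligand binding, with a stated time of 180 min; a lower number here means a stronger inhibitor, a higher number a weaker inhibitor. Compound 1 `Clc1ccc(-c2nc(N3CCCCC3)c3nc[nH]c3n2)cc1Cl` gives 79.4 nM in this assay. Compound 2 `Clc1ccc(-c2nc(N3CCCCC3)c3nc[nH]c3n2)cc1` gives 7.94 nM in this assay. Compound 3 `Clc1ccc(Cl)c(-c2nc(N3CCCCC3)c3nc[nH]c3n2)c1` gives 200 nM in this assay. Within the data shown here, the only pair differing in one place is a 10-fold lower number from compound 1 to compound 2 (1.00 log units; beyond the scatter), hydrogen in place of chloro on an aromatic carbon. Compound 2 stands lowest of the three numbers; compound 1 is nearest to it and compound 3 furthest, with the higher number of the two.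

Compound 4 `CN1CCN(c2nc(-c3ccc(Cl)cc3)nc3[nH]cnc23)CC1` has not yet been measured. It differs from compound 2 by 4-methylpiperazin-1-yl in place of piperidin-1-yl on an aromatic carbon, next to the ring nitrogen and meta to the 4-chlorophenyl group. Among the measured compounds shown here, no measured step bears on this change: the one step in hand concerns the chloro substitution on the chlorophenyl group, not the amine. Without a precedent, a modest step in either direction is the reasonable expectation, and compound 4 is expected to show a 3.1-fold higher number from compound 2 to compound 4 (0.50 log units; beyond the scatter). The estimate for compound 4 is 25 nM, with a range from 5 nM to 150 nM.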

Compound 4, inhibition constant: 39.8 nM
Beside the measured number, compound 4's estimate is 1.6-fold (0.20 log units) below it; measured number inside the range.
By their numbers in this assay, from the lowest: compound 2; then compounds 4 and 1 (each within the scatter of the next); then compound 3.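

In this assay, the change gives a 5.0-fold higher number from compound 2 to compound 4 (0.70 log units; beyond the scatter), the first sign that the amine on the shared core affects the number, since compounds 1, 2 and 3 all carry piperidin-1-yl and speak only to the chloro substitution on the phenyl group. The step is read as modest, and with 4-methylpiperazin-1-yl in place, compound 4 still gives 39.8 nM, so this position accepts a second ring nitrogen and a methyl group at a measurable but higher number. Nothing measured here explains why the number rises, and the swap changes the ring nitrogen and the methyl group together, so the step cannot be assigned to either one.

The compounds shown leave open how piperazin-1-yl without the methyl group, morpholin-4-yl or a piperazine bearing a longer chain such as propyl would compare with these two amines. Among these compounds, they also leave open whether the same step would appear with the chloro pattern of compound 1 or compound 3, as the amine change is seen only with the 4-chlorophenyl group.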